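The compounds below may be only part of what the source reports. "The series", "measured", "known", "first", "only" and "open" are said of these compounds alone.

Measured in a functional assay on MCF-10A cells (Homo sapiens) for antiproliferative activity, with a stated time of 48 h; on this read-out lower numbers stand for an effect already at smaller amounts and higher numbers for an effect only at larger amounts of compound:
- Compound 1 `COc1ccc2nc(C)cc(NCc3cccnc3)c2c1`: 44800 nM
- Compound 2 `COc1cccc(CNc2cc(C)nc3ccc(OC)cc23)c1`: 9700 nM
- Compound 3 `COc1ccc2nc(C)cc(NCc3ccc(F)c(OC)c3)c2c1`: 9500 nM

In this assay, compound 2, at 9700 nM, is on a par with compound 3, at 9500 nM, while compound 1, at 44800 nM, shows a clearly higher number than both.

The next compound is compound 4 `COc1ccc2nc(C)cc(NCc3cccc(CO)c3)c2c1`, in which hydroxymethyl stands in place of methoxy on an aromatic carbon (hydroxymethyl in place of methoxy on an aromatic carbon). Among the measured compounds shown here, no measured step covers this exchange. For the measured compounds named here, the only step available, a 1.0-fold lower number from compound 2 to compound 3 (0.01 log units; within the scatter), comes from a different change, fluoro in place of hydrogen on an aromatic carbon, and it stays within the scatter. It therefore offers only weak guidance, and nothing in the data points to a large shift in this assay. The direction remains uncertain, with a slightly higher number marginally more likely. The expected step is a 1.2-fold higher number from compound 2 to compound 4 (0.09 log units; within the scatter), which is estimated to stay within the scatter. The estimate for compound 4 is 12000 nM, with an expected range from 5000 nM to 30000 nM.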

Compound 4, half-maximal effective concentration: 17100 nM
Beside the measured number, compound 4's estimate is 1.4-fold (0.15 log units) below it; measured number inside the range.
By their numbers in this assay, from the lowest: compounds 3, 2 and 4 (each within the scatter of the next); then compound 1.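

In this assay, hydroxymethyl in place of methoxy on an aromatic carbon, meta to a large group, gives a 1.8-fold higher number from compound 2 to compound 4 (0.25 log units; within the scatter). This is the first exchange shown at this place, as the earlier step concerned fluoro in place of hydrogen, and it shows that a group with a hydrogen-bond donor can replace one without a donor while compound 2 and compound 4 stay within the scatter of each other. No measured evidence bears on this result, so the data offer no explanation for it.

The compounds shown leave open whether an amine, a carboxylic acid or a longer chain at this place would also stay within the scatter of compound 2. They also leave open how fluoro would act alongside hydroxymethyl on the same ring.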